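Changing the Group on the Chain Carbon of Glucagon Ligands

A few compounds are considered here, and "the series" means these few. Any claim that something is new, unique, unknown or untested is made for them only; others in the source may bear on it.

Three compounds have been measured in an assay on cells for displacement of a labelled ligand from Glucagon receptor (Homo sapiens), in the presence of a further agent that is not named here; on this read-out higher numbers stand for weaker inhibition and lower numbers for stronger inhibition:
- Compound 1, `CCC(Oc1ccc(-n2cc(C(F)(F)F)cn2)cc1)c1ccc(C(=O)NCCC(=O)O)cc1`, gives 1400 nM.
- Compound 2, `O=C(O)CCNC(=O)c1ccc(C(Oc2ccc(-n3cc(C(F)(F)F)cn3)cc2)C2CC2)cc1`, gives 1300 nM.
- Compound 3, `CCCC(Oc1ccc(-n2cc(C(F)(F)F)cn2)cc1)c1ccc(C(=O)NCCC(=O)O)cc1`, gives 890 nM.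

Compound 3 shows the lowest of the three numbers, yet the steps leading to it, a 1.6-fold lower number from compound 1 to compound 3 (0.20 log units; within the scatter) and a 1.5-fold lower number from compound 2 to compound 3 (0.16 log units; within the scatter), both fall within the usual scatter, so the three compounds cannot be told apart on these data.

The next compound, compound 4, `CC(C)(C)C(Oc1ccc(-n2cc(C(F)(F)F)cn2)cc1)c1ccc(C(=O)NCCC(=O)O)cc1`, differs from compound 3 by tert-butyl in place of propyl on a saturated chain carbon bound to an aromatic carbon and an oxygen on an aromatic ring.

Two of the measured steps alter this same chain carbon and therefore bear on the new change: a 1.1-fold lower number from compound 1 to compound 2 (0.03 log units; within the scatter) and a 1.5-fold lower number from compound 2 to compound 3 (0.16 log units; within the scatter). Among the compounds with values here, neither reached beyond the scatter, and none of the three groups tried so far is tert-butyl, so there is no direct precedent for this group. Taking the three earlier groups as the guide, no step beyond the scatter is expected for compound 4 in this assay. Compound 4 is therefore estimated at 1000 nM, with a range from 400 nM to 2500 nM. This estimate for compound 4 amounts to a 1.1-fold higher number from compound 3 to compound 4 (0.05 log units; within the scatter).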

Compound 4, inhibition constant: 170 nM
For compound 4 the middle estimate is 5.9-fold (0.77 log units) above the measured one, outside the stated range (below it).
By their numbers in this assay, from the lowest: compound 4; then compounds 3, 2 and 1 (each within the scatter of the next).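

In this assay, the group on this chain carbon proves able to move the number after all: ethyl, cyclopropyl and propyl could not be told apart, whereas tert-butyl gives a 5.2-fold lower number from compound 3 to compound 4 (0.72 log units; beyond the scatter), a 7.6-fold lower number from compound 2 to compound 4 (0.88 log units; beyond the scatter) and an 8.2-fold lower number from compound 1 to compound 4 (0.92 log units; beyond the scatter), all beyond the usual scatter. Going from ethyl to propyl gave only a 1.6-fold lower number from compound 1 to compound 3 (0.20 log units; within the scatter), so a larger group on this carbon does not in itself bring a clear step, and among these four compounds only tert-butyl stands apart from the rest. Nothing available here explains why tert-butyl behaves differently from the other three groups.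

The compounds shown leave open whether the lower number belongs to tert-butyl alone or extends to other groups on this carbon, such as isopropyl, neopentyl or 1-methylcyclopropyl. They also leave open whether the same step would appear if the trifluoromethyl group on the far side of the molecule were replaced, for example by a nitrile or a chlorine atom.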